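The source may hold more compounds than are shown below. What is called first, only, known or untested is meant among the compounds shown, and "the series" means these compounds.

Measured compounds in a functional assay on PC-3 cells (Homo sapiens) for cytotoxicity, read by sulforhodamine B assay, with a stated time of 48 h; on this read-out lower numbers stand for stronger inhibition of growth and higher numbers for weaker inhibition of growth:
compound 1, `COc1ccc(-c2cs/c(=N\NC(=O)c3ccc(O)cc3)n2-c2ccc(OC)cc2OC)cc1`, < 100000 nM
compound 2, `O=C(c1ccc(O)cc1)n1nc(-c2c(Cl)cccc2Cl)sc1=S`, 30200 nM

Compound 1 stands only at a limit of this assay, not at a number: for compound 1 the read-out is < 100000 nM, which is the limit of < 100000 nM in this assay, at which 1 of the 2 values shown sits. Compound 2 gives a measured value in this assay, 30200 nM; the two compounds share no single-point change, so their values are simply set side by side. Compound 3, `COc1ccc(-n2c(-c3ccc(Cl)cc3)cs/c2=N\NC(=O)c2ccc(O)cc2)c(OC)c1`, is not yet measured. It differs from compound 1 by chloro in place of methoxy on an aromatic carbon. With compound 1 known only as a limit, no step in this assay can be sized from the numbers shown, and the change is expected to move the read-out by little, if at all, beyond the usual scatter. The step from compound 1 to compound 3 is estimated as a step that the limit leaves unreadable from compound 1 to compound 3. Compound 3 is therefore expected near 30000 nM, within 8000 nM to 100000 nM.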

Compound 3, concentration for total growth inhibition: < 100000 nM
Compound 3: only a limit was reported; the forecaster's own chance of this, stated with the estimate: 35%; the middle value does not contradict the limit.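

Compound 1 and compound 3 both stand as limits in this assay, so no step can be read between them: the limit of < 100000 nM in this assay, at which 2 of the 3 values shown sit.

The compounds shown leave open whether chloro in place of methoxy on an aromatic carbon changes growth inhibition at all, and by how much.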